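Replacing the pyridin-3-yl group of compound 2

This account rests on a few compounds, and the source may have more. Where it says the series, first, only, none or still open, it means among the compounds named here.

In a functional assay (trachea) with Cavia porcellus as the target (a lower number here means a stronger inhibitor, a higher number a weaker inhibitor), compound 2 `CCn1nc(-c2cccnc2)c2ccccc2c1=O` gives 1320 nM and holds the lowest of the three numbers, against compound 1 `Cn1nc(-c2cccnc2)c2ccccc2c1=O` at 11500 nM and compound 3 `CC(=O)Cn1nc(-c2cccnc2)c2ccccc2c1=O` at 40700 nM in the same read-out. Compound 4 `CCn1nc(-n2cncn2)c2ccccc2c1=O` has 1H-1,2,4-triazol-1-yl in place of pyridin-3-yl on an aromatic carbon on an aromatic carbon next to the ring nitrogen. For the measured compounds named here, no measured step touches this place. The steps at the saturated chain carbon, an 8.7-fold lower number from compound 1 to compound 2 (0.94 log units; beyond the scatter) (modest), a 3.5-fold higher number from compound 1 to compound 3 (0.55 log units; beyond the scatter) (modest) and a 31-fold higher number from compound 2 to compound 3 (1.49 log units; beyond the scatter) (large), bear on it only indirectly, as a guide to size. The step expected in this assay is a 3.0-fold higher number from compound 2 to compound 4 (0.48 log units; beyond the scatter) and is modest, though its direction is weakly supported. Compound 4 is expected at 4000 nM within an estimated range from 500 nM to 30000 nM (estimate only).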

Compound 4, half-maximal inhibitory concentration: 15800 nM
For compound 4 the middle estimate is 4.0-fold (0.60 log units) below the measured one; low and high end bracket the measured number.
By their numbers in this assay, from the lowest: compound 2; then compounds 1 and 4 (each within the scatter of the next); then compound 3.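

In this assay, for the compounds shown here, 1H-1,2,4-triazol-1-yl in place of pyridin-3-yl gives a 12-fold higher number from compound 2 to compound 4 (1.08 log units; beyond the scatter), the first reading at this aromatic carbon. The position is therefore not indifferent to the group it carries, and this five-membered aromatic ring does not stand in for pyridin-3-yl without a large loss. Nothing available accounts for this step.

As far as these compounds go, a phenyl group or a pyridin-4-yl group at this carbon remains open, as does an amine on the ring. From the compounds shown here alone, whether the step holds with the chains of compound 1 and compound 3 is also open.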